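Butylamino in Place of Tert-Butoxy: Compound 2 to Compound 3

A few compounds are considered here, and "the series" means these few. Any claim that something is new, unique, unknown or untested is made for them only; others in the source may bear on it.

Of the compounds shown here, two have so far been measured in a functional assay on HEK293 cells for agonist activity at nuclear receptor subfamily 1 group D member 1 (Homo sapiens), read by a luciferase reporter, with a stated time of 24 h; a lower number here means that less compound is needed, a higher number that more compound is needed for the effect. Compound 1 `O=[N+]([O-])c1ccc(CN(Cc2ccc(Cl)cc2)CC2CCCCC2)s1` gives 7400 nM in this assay. Compound 2 `CC(C)(C)OC(=O)N1CCC(CN(Cc2ccc(Cl)cc2)Cc2ccc([N+](=O)[O-])s2)C1` gives 1800 nM in this assay, the lowest of the two numbers; compound 1 shows the higher number, and the gap between the two lies beyond the usual scatter. For the measured compounds named here, these two compounds differ in more than one place, so no single-point step is counted between them.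

Compound 3 `CCCCNC(=O)N1CCC(CN(Cc2ccc(Cl)cc2)Cc2ccc([N+](=O)[O-])s2)C1` has not yet been measured. It differs from compound 2 in one place only: butylamino in place of tert-butoxy on a carbonyl carbon. Going by the values given here, no measured pair in this set carries that change, so there is no step to lean on. With nothing to point in either direction, only a small step is expected, a 1.1-fold higher number from compound 2 to compound 3 (0.05 log units; within the scatter), likely not beyond the scatter. Compound 3 is therefore estimated to give 2000 nM in this assay, with a range from 700 nM to 6000 nM considered plausible.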

Compound 3, half-maximal effective concentration: 670 nM
Beside the measured number, compound 3's estimate is 3.0-fold (0.47 log units) above it; measured number below the stated range.
By their numbers in this assay, from the lowest: compound 3; then compound 2; then compound 1.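

The earlier compounds shown here differed in more than one place and so could not speak to any single position, whereas this change isolates one: on the carbonyl carbon whose other neighbour is the amide-type nitrogen in a ring, butylamino in place of tert-butoxy gives in this assay a 2.7-fold lower number from compound 2 to compound 3 (0.43 log units; beyond the scatter). The number therefore responds to what sits on this carbonyl carbon, even though the heavy-atom count stays at 5 and no ring or net charge enters or leaves. What does change is that a carbon chain attached through nitrogen, with 1 hydrogen-bond donor, replaces one attached through oxygen, with 1 hydrogen-bond acceptor, but no measurement here ties the shift in the number to any of these differences.

The compounds shown leave open whether the lower number follows the amide hydrogen or the butyl chain itself, a question that tert-butylamino or butoxy on the same carbonyl carbon would address. They also leave open how the number responds to a longer chain such as hexylamino, or to a ring-bearing group such as phenylamino, at this position.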